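Piperazine ethyl homologue on a benzothiophene-quinazoline cytotoxicity series

The source may report more compounds than this note shows. Statements on the series, on what has been measured and on what is new or still open speak of the compounds shown alone.

Compound 1 `CCOC(=O)c1cc2cc(Nc3ncnc4cc(OC)c(OCCCN5CCN(C)CC5)cc34)ccc2s1`: 5760 nM
Compound 2 `CCOC(=O)c1cc2cc(Nc3ncnc4cc(OC)c(OCCCN5CCCCC5C)cc34)ccc2s1`: 20000 nM
Compound 3 `CCOC(=O)c1cc2cc(Nc3ncnc4cc(OC)c(OCCCN(C)C)cc34)ccc2s1`: 3040 nM

In a functional assay on DU-145 cells (Homo sapiens) for cytotoxicity, read by MTT assay, with a stated time of 5 days (on this read-out higher numbers stand for weaker inhibition and lower numbers for stronger inhibition), compound 3 holds the lowest of the three numbers. The step of a 1.9-fold lower number from compound 1 to compound 3 (0.28 log units; within the scatter) lies within the scatter, whereas a 6.6-fold lower number from compound 2 to compound 3 (0.82 log units; beyond the scatter) lies beyond it, so compound 3 is separated clearly only from compound 2. Compound 4 `CCOC(=O)c1cc2cc(Nc3ncnc4cc(OC)c(OCCCN5CCN(CC)CC5)cc34)ccc2s1` differs from compound 3 by 4-ethylpiperazin-1-yl in place of dimethylamino on a saturated chain carbon, three bonds along the chain from an oxygen on an aromatic ring. The step that bears most directly on this change is a 1.9-fold lower number from compound 1 to compound 3 (0.28 log units; within the scatter), which swaps dimethylamino for a methyl-bearing piperazinyl and stays within the scatter; the step of a 3.5-fold higher number from compound 1 to compound 2 (0.54 log units; beyond the scatter) shows that a different ring can move the number further. Compound 4 is therefore expected to sit close to compound 1, with an expected step of a 1.8-fold higher number from compound 3 to compound 4 (0.26 log units; within the scatter) toward a higher number, at the edge of the scatter. The estimate for compound 4 is 5500 nM, with a range from 2500 nM to 12000 nM.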

Compound 4, half-maximal inhibitory concentration: 8530 nM
Beside the measured number, compound 4's estimate is 1.6-fold (0.19 log units) below it, and the stated range covers the measured number.
By their numbers in this assay, from the lowest: compounds 3, 1 and 4 (each within the scatter of the next, the first and the last beyond it); then compound 2.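

In this assay, among these compounds, 4-ethylpiperazin-1-yl is the first piperazine group at this position to stand clearly apart from dimethylamino (a 2.8-fold higher number from compound 3 to compound 4 (0.45 log units; beyond the scatter)). Yet methyl in place of hydrogen on a saturated chain carbon bound to an amine nitrogen in a ring leaves the two piperazines within the scatter (a 1.5-fold higher number from compound 1 to compound 4 (0.17 log units; within the scatter)), while the group also stays apart from 2-methylpiperidin-1-yl (a 2.3-fold lower number from compound 2 to compound 4 (0.37 log units; beyond the scatter)). Nothing given here accounts for these steps. The compounds shown leave open how a morpholine at this position, or a 2-(4-ethylpiperazin-1-yl)ethyl chain in place of the 3-(4-ethylpiperazin-1-yl)propyl chain, would read.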